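A few compounds are considered here, and "the series" means these few. Any claim that something is new, unique, unknown or untested is made for them only; others in the source may bear on it.

Working notes on the amide-nitrogen series. Compound 1 `Nc1sc(-c2ccc(Cl)cc2)c(-c2ccc(Cl)cc2)c1C(=O)Nc1ccccc1` and compound 2 `CC(C)(C)NC(=O)c1c(N)sc(-c2ccc(Cl)cc2)c1-c1ccc(Cl)cc1` share one core and differ only in the group on the amide-type nitrogen. In a functional assay on PC-3 cells (Homo sapiens) for inhibition, read by sulforhodamine B assay, with a stated time of 72 h (on this read-out higher numbers stand for weaker inhibition and lower numbers for stronger inhibition), compound 1 gives > 50000 nM, which is a limit of the assay and not a number. In this assay, within the data shown here, compound 2 gives 15100 nM, the only number so far. The step of an at least 3.3-fold lower number from compound 1 to compound 2 (0.51 log units; beyond the scatter) can only be stated as a lower bound because of the limit of > 50000 nM in this assay, at which 1 of the 2 values shown sits.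

Compound 3 `Nc1sc(-c2ccc(Cl)cc2)c(-c2ccc(Cl)cc2)c1C(=O)NC1CC1` is the next member, differing from compound 2 by cyclopropyl in place of tert-butyl on an amide-type nitrogen. Among the measured compounds shown here, the single measured step bears on it only loosely: it swapped an aromatic group for an alkyl group at the same nitrogen, whereas the present change trades one alkyl group for a smaller one. For the measured compounds named here, no measured pair informs the size of such a trade, so a step within the scatter is expected, with a slight lean toward a higher number, giving a 1.3-fold higher number from compound 2 to compound 3 (0.12 log units; within the scatter) as the expected change from compound 2 to compound 3. For compound 3 the expected value in this assay is 20000 nM, within 8000 nM to 50000 nM.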

Compound 3, half-maximal inhibitory concentration: 3680 nM
Compound 3: the middle estimate sits 5.4-fold (0.74 log units) above what was measured; the whole stated range lies above it.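

In this assay, the amide-type nitrogen responds to a change between two alkyl groups as well as to the earlier swap of an aromatic group for an alkyl group: cyclopropyl in place of tert-butyl gives a 4.1-fold lower number from compound 2 to compound 3 (0.61 log units; beyond the scatter). Compound 3 is therefore the strongest of the three shown, and among these three the order at this position runs from phenyl through tert-butyl to cyclopropyl, with each step beyond the scatter. Cyclopropyl in place of phenyl gives an at least 13-fold lower number from compound 1 to compound 3 (1.13 log units; beyond the scatter), which is a lower bound and not a measured size, because one end of the step is a limit of the assay and not a number: the limit of > 50000 nM in this assay, at which 1 of the 3 values shown sits.

The single step from tert-butyl to cyclopropyl changes the heavy-atom count and introduces a ring together, so the compounds shown cannot say which of the two goes with the lower number. Isopropyl or cyclobutyl on the same nitrogen would begin to separate the two, while a chain carrying a hydroxyl group or an amine would test a kind of substituent absent from this set.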